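Moving the chlorine on the phenyl ring of an unsaturated ester

The source may report more compounds than this note shows. Statements on the series, on what has been measured and on what is new or still open speak of the compounds shown alone.

Measured so far:
compound 1 `COc1cc(OC)c(OC)cc1/C=C/COC(=O)/C=C/c1ccc(OC)c(OC)c1` gives 0%
compound 2 `COc1cc(OC)c(OC)cc1/C=C/COC(=O)/C=C/c1ccccc1Cl` gives 25%

Both compounds were tested in a functional assay on the whole organism (strain Kunming) with Mus musculus as the target, with a stated time of 0.5 h, at a dose of 300 mg/kg by the intraperitoneal route; on this read-out lower numbers stand for a stronger effect and higher numbers for a weaker effect at the one dose given. Compound 2 holds the highest of the two numbers, and since lower numbers mean a stronger effect, compound 2 shows the weaker effect of the pair: its step of a number 25 percentage points higher from compound 1 to compound 2 (beyond the scatter) lies beyond the scatter and counts as modest.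

Compound 3 `COc1cc(OC)c(OC)cc1/C=C/COC(=O)/C=C/c1ccc(Cl)cc1` is the next compound. Its difference from compound 2 is 4-chlorophenyl in place of 2-chlorophenyl on a double-bonded chain carbon bound to a double-bonded chain carbon. The two compounds contain the same atoms, joined differently, so the whole change is where the chlorine sits on the ring.

For the measured compounds named here, no measured step bears directly on this change: the single step from compound 1 to compound 2 swapped 3,4-dimethoxyphenyl for 2-chlorophenyl, and it says nothing about one chlorophenyl against another. Without such evidence, compound 3 is expected to stay near compound 2, with a step of no change at the digits printed from compound 2 to compound 3 (within the scatter) that is not beyond the scatter. Compound 3 is therefore estimated at 25%, within a range from 5% to 50%.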

Compound 3, a percentage reported as activity, at one dose (the size of the read-out at that dose, not a potency): 25%
Compound 3: middle estimate and measured number agree at the digits printed; the measured number falls inside the stated range.
By their numbers in this assay, from the lowest: compound 1; then compounds 2 and 3 (each within the scatter of the next).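

Swapping 2-chlorophenyl for 4-chlorophenyl on the double-bonded chain carbon gives no change at the digits printed from compound 2 to compound 3 (within the scatter) in this assay, so at this place on the chain this test cannot tell the two chlorophenyl groups apart. The step away from 3,4-dimethoxyphenyl now appears with a second chlorophenyl group, as a number 25 percentage points higher from compound 1 to compound 3 (beyond the scatter) alongside the earlier a number 25 percentage points higher from compound 1 to compound 2 (beyond the scatter), so in these two compounds the weaker effect does not depend on which of the two named ring positions holds the chlorine. Nothing available explains why the two chlorophenyl compounds read alike or why both read differently from compound 1.

Still open, as far as these compounds go, is whether bromine or a nitrile in place of the chlorine, or an amine on the same phenyl ring, would bring the number back towards that of compound 1. The read-out also comes from a single dose and gives the size of the effect there rather than a potency, so compound 2 and compound 3 could still part ways at other doses.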